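Flipping One Stereocentre: From Compound 3 to Compound 4

This account rests on a few compounds, and the source may have more. Where it says the series, first, only, none or still open, it means among the compounds named here.

Measured so far:
- compound 1, `Cc1ccccc1NC(=O)N[C@@H](C)c1ccccc1`: in an ADME assay on the whole organism with Oryza sativa as the target, tested at 1 uM (a lower number here means a stronger effect, a higher number a weaker effect of the compound at the concentration tested), compound 1 gives 99%
- compound 2, `Cc1cccc(NC(=O)N[C@H](C)c2ccccc2)c1`: in this assay compound 2 gives 98%
- compound 3, `Cc1ccc(NC(=O)N[C@H](C)c2ccccc2)cc1`: in this assay compound 3 gives 98%

The three compounds share one core and differ in where a methyl sits on one ring and in the drawn configuration at a single saturated chain carbon. All three numbers lie within the scatter of one another. Compound 3 is level with compound 2 at the digits shown, and its furthest neighbour, compound 1, sits only a little higher, still within the scatter. No ordering among them can be read from these numbers.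

Compound 4, `Cc1ccc(NC(=O)N[C@@H](C)c2ccccc2)cc1`, has not yet been measured. The change from compound 3 is the two compounds have the same atoms and bonds and differ only in configuration as drawn: 1 of 1 stereo elements differ; a stereocentre at a saturated chain carbon is drawn R in compound 3 and S in compound 4. Nothing leaves and nothing enters.

Since compound 1 already carries the other drawn configuration and gives a number within the scatter of compound 3, no step beyond the scatter is expected from compound 3 to compound 4, so the expected step is no change at the digits printed from compound 3 to compound 4 (within the scatter). Compound 4 is therefore estimated to give 98%, with a range from 92% to 100%, because in this assay compound 1 gives 99% with the same drawn configuration at that carbon.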

Compound 4, a percentage reported as activity, at one concentration (the size of the read-out at that concentration, not a potency): 99%
Compound 4: middle estimate off by 1 percentage points, on the low side; low and high end bracket the measured number.
By their numbers in this assay, from the lowest: compounds 2, 3, 1 and 4 (each within the scatter of the next).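

Within the data shown here, compound 3 and compound 4 form the first pair here in which the stereocentre at the saturated chain carbon can be judged on its own, with the methyl left in the same place on the ring: the fact that compounds 3 and 4 differ only in the configuration as drawn. In this assay the result is a number 1 percentage points higher from compound 3 to compound 4 (within the scatter), so for this pair, drawing that carbon as S rather than R gives a difference that cannot be told apart from the usual scatter. Among these compounds, no earlier pair could show this, since the compounds before compound 4 never differed in one place alone.

As far as these compounds go, whether the configuration would remain this silent with a carboxylic acid or an amine in place of the ring methyl, or with a longer chain in place of the methyl at the stereocentre, stays open. The compounds shown also leave open which part of the structure, if any, can move this read-out.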